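A few compounds are considered here, and "the series" means these few. Any claim that something is new, unique, unknown or untested is made for them only; others in the source may bear on it.

Compound 1 `CC1=NN(c2ccc(Br)cc2)C(=O)C12C=CC(=O)C=C2c1cccc(C)c1` is examined in a functional assay on HCT-116 cells (Homo sapiens) for antiproliferative activity, read by CCK-8 assay, with a stated time of 72 h; on this read-out lower numbers stand for stronger inhibition and higher numbers for weaker inhibition. In this assay compound 1 returns only a limit, > 100000 nM. Compound 2 `CC1=NN(c2ccc(Br)cc2)C(=O)C12C=CC(=O)C=C2c1ccccc1` differs from it by hydrogen in place of methyl on an aromatic carbon. In this assay compound 2 likewise reaches only a limit, > 100000 nM. Compound 3 `CC1=NN(c2ccc(Cl)cc2)C(=O)C12C=CC(=O)C=C2c1ccccc1` carries chloro in place of bromo on an aromatic carbon. In this assay compound 3 also gives only a limit, > 100000 nM. The steps a step that the two limits leave unreadable from compound 1 to compound 2 and a step that the two limits leave unreadable from compound 2 to compound 3 cannot be sized because of the limit of > 100000 nM in this assay, at which 3 of the 3 values shown sit. Compound 1 thus stands at the limit, with no number of its own. Compound 4 `CC1=NN(c2cccc(Cl)c2)C(=O)C12C=CC(=O)C=C2c1cccc(C)c1` remains to be measured; it differs from compound 1 by 3-chlorophenyl in place of 4-bromophenyl on an amide-type nitrogen in a ring. Only these two unreadable steps bear on the change, and neither yields a direction or a size, so no movement beyond the scatter can be foreseen in this assay. The step from compound 1 to compound 4 is expected to be a step that the limit leaves unreadable from compound 1 to compound 4. Compound 4 is accordingly estimated at 150000 nM, within 50000 nM to 500000 nM, most probably reported again only as a limit.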

Compound 4, half-maximal inhibitory concentration: 3740 nM
Beside the measured number, compound 4's estimate is 40-fold (1.60 log units) above it; measured number below the stated range.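

In this assay, going by these compounds alone, 3-chlorophenyl in place of 4-bromophenyl on the amide-type nitrogen in a ring produces an at least 26-fold lower number from compound 1 to compound 4 (1.42 log units; beyond the scatter), the first change that can be sized. The earlier steps shown here cannot be read: the limit of > 100000 nM in this assay, at which 3 of the 4 values shown sit. Both groups count 7 heavy atoms and one six-membered aromatic ring of carbon only, so this nitrogen substituent is the first place shown where a change in the aryl group moves the read-out to a measured number, and that change involves only the identity and placement of the halogen.

The compounds shown do not separate the change of halogen from the change of its place on the ring, as the step alters both at once. As far as these compounds go, it remains open whether a 3-bromophenyl or 3-methoxyphenyl group at this nitrogen would also give a measured number.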